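Amide terminus swap in a bis-sulfonamide piperidine series

The source may report more compounds than this note shows. Statements on the series, on what has been measured and on what is new or still open speak of the compounds shown alone.

Three compounds have numbers in a functional assay on BXPC-3 cells (Homo sapiens) for inhibition, read by MTT assay, with a stated time of 7 days; on this read-out lower numbers stand for stronger inhibition and higher numbers for weaker inhibition. Compound 1 `O=C([C@@H]1CCCN(S(=O)(=O)c2ccc(S(=O)(=O)N3CC[C@@H](O)C3)cc2)C1)N1CCC(F)(F)CC1` gives 330 nM, compound 2 `CCN(CC)S(=O)(=O)c1ccc(S(=O)(=O)N2CCC[C@@H](C(=O)N3CCOCC3)C2)cc1` gives 790 nM, and compound 3 `O=C([C@@H]1CCCN(S(=O)(=O)c2ccc(S(=O)(=O)N3CC[C@H](O)C3)cc2)C1)N1CCC(F)(F)CC1` gives 580 nM. For the measured compounds named here, the only single-point step measured is a 1.8-fold higher number from compound 1 to compound 3 (0.24 log units; within the scatter), and it rests on the fact that compounds 1 and 3 differ only in the configuration as drawn: the two compounds are one and the same connectivity drawn in opposite configuration at one ring carbon. Compound 2 gives the highest number of the three; its gap to compound 3 lies within the scatter, its gap to compound 1 beyond it.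

Compound 4 `CCN(CC)S(=O)(=O)c1ccc(S(=O)(=O)N2CCC[C@@H](C(=O)N3CCS(=O)(=O)CC3)C2)cc1` differs from compound 2 by 1,1-dioxothiomorpholin-4-yl in place of morpholin-4-yl on a carbonyl carbon. Going by the values given here, no measured step touches the amide terminus; the one step known concerns configuration at a ring carbon, and it stayed within the scatter. There is thus no basis for expecting a step beyond the scatter in this assay , in either direction. The expected step is no change at the digits printed from compound 2 to compound 4 (within the scatter). For compound 4 the estimate is 790 nM, with a range of 300 nM to 2100 nM.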

Compound 4, half-maximal inhibitory concentration: 4430 nM
Compound 4: the middle estimate sits 5.6-fold (0.75 log units) below what was measured; the whole stated range lies below it.
By their numbers in this assay, from the lowest: compounds 1, 3 and 2 (each within the scatter of the next, the first and the last beyond it); then compound 4.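

For the compounds shown here, the amide terminus is the first place where a single change moves the number in this assay beyond the scatter: a 5.6-fold higher number from compound 2 to compound 4 (0.75 log units; beyond the scatter), with 1,1-dioxothiomorpholin-4-yl in place of morpholin-4-yl on a carbonyl carbon. The only earlier step, a 1.8-fold higher number from compound 1 to compound 3 (0.24 log units; within the scatter), changed configuration at a ring carbon, so this terminus is the one place shown so far where the read-out responds clearly, and the response here is a weaker number. The one fact at hand concerns configuration at another ring carbon and does not bear on this swap.

From the compounds shown here alone, whether the ring sulfur or its oxygens carry the step stays open, and thiomorpholin-4-yl or piperazin-1-yl on the same carbonyl carbon would help separate them. Also open, going by these compounds, is whether this swap gives a similar step on the core of compound 1.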